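The compounds below may be only part of what the source reports. "The series", "measured", "known", "first", "only" and "open" are said of these compounds alone.

Measured so far:
compound 1 `CC(C(=O)N1CCN(c2ccccc2)CC1)N1C(=O)CCC1=O` — 0%
compound 2 `CCC(C(=O)N1CCN(c2cccc(C)c2)CC1)N1C(=O)CCC1=O` — 0%
compound 3 `CC(C(=O)N1CCN(c2cccc(C(F)(F)F)c2)CC1)N1C(=O)CCC1=O` — 75%

In a functional assay on the whole organism (strain Swiss) with Mus musculus as the target, in the maximal electroshock model, with a stated time of 0.5 h, at a dose of 100 mg/kg by the intraperitoneal route (on this read-out lower numbers stand for a weaker effect and higher numbers for a stronger effect at the one dose given), compound 3 stands highest of the three numbers; compound 1 and compound 2 both lie well beneath it, each beyond the scatter. Among the measured compounds shown here, the one single-point step measured so far is a number 75 percentage points higher from compound 1 to compound 3 (beyond the scatter), a large gain on introducing trifluoromethyl in place of hydrogen on an aromatic carbon.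

Compound 4 `Cc1cccc(N2CCN(C(=O)C(C)N3C(=O)CCC3=O)CC2)c1` differs from compound 3 as follows: methyl in place of trifluoromethyl on an aromatic carbon. The step from compound 1 to compound 3 bears on this directly, since it shows that without the trifluoromethyl compound 1 reads 0%. For the measured compounds named here, compound 2 also carries methyl on the ring, though with a longer chain, and reads 0%; no single-point step links it to compound 3. Taken together, a large fall in this assay is expected, with the estimated step being a number 60 percentage points lower from compound 3 to compound 4 (beyond the scatter).

Compound 4 is therefore expected to give 15% in this assay, within a range from 0% to 50%.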

Compound 4, a percentage reported as activity, at one dose (the size of the read-out at that dose, not a potency): 0%
Beside the measured number, compound 4's estimate is 15 percentage points above it; the measured number falls inside the stated range.
By their numbers in this assay, from the lowest: compounds 1, 2 and 4 (each within the scatter of the next); then compound 3.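

Methyl does not replace trifluoromethyl at this aromatic carbon, meta to a large group: in this assay the read-out shows a number 75 percentage points lower from compound 3 to compound 4 (beyond the scatter). Methyl also gives no gain over hydrogen at this position, with no change at the digits printed from compound 1 to compound 4 (within the scatter), so among these compounds the activity appears only with trifluoromethyl. The chain change, read as no change at the digits printed from compound 2 to compound 4 (within the scatter), shows no effect in the methyl-bearing pair, but this pair says nothing about the same change with trifluoromethyl on the ring. No measured property in hand bears on this result.

The compounds shown leave open whether a chlorine, a methoxy group or a nitrile at this position would give a reading like that of compound 3. They also leave open whether compound 3 would keep its reading with a longer chain.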